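A Five-Membered Ring in Place of a Six-Membered Ring

The source may hold more compounds than are shown below. What is called first, only, known or untested is meant among the compounds shown, and "the series" means these compounds.

Of the compounds shown here, two with a shared core have numbers so far. In a functional assay on HT cells (Homo sapiens) for antiproliferative activity, read by fluorescence, with a stated time of 72 h (a higher number here means a weaker inhibitor of growth, a lower number a stronger inhibitor of growth), compound 1 `CC(C)c1n[nH]c2c(NCc3ccc(-c4ccccn4)cc3)nc(SCC(O)CN3CCNCC3)nc12` gives 332 nM, and compound 2 `CC(C)c1n[nH]c2c(NCc3ccc(-c4ccccn4)cc3)nc(SC3CCCCC3O)nc12` gives 636 nM. These two numbers lie within the usual scatter of each other, so compound 2 cannot be separated from compound 1 on this evidence.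

Compound 3 `CC(C)c1n[nH]c2c(NCc3ccc(-c4ccccn4)cc3)nc(SC3CCCC3O)nc12` keeps the core of compound 2 and alters one group: 2-hydroxycyclopentyl in place of 2-hydroxycyclohexyl on a sulfur. Among the compounds with values here, only one measured step concerns this sulfur, a 1.9-fold higher number from compound 1 to compound 2 (0.28 log units; within the scatter), and it stays within the scatter. Within the data shown here, that step exchanged 2-hydroxy-3-(piperazin-1-yl)propyl for 2-hydroxycyclohexyl, so it says nothing direct about ring size, and no measured pair tests ring size alone. Even so, it gives no reason to expect a large shift from swapping one hydroxylated carbon ring for another, so no change beyond the scatter is expected in this assay. The estimated step is a 1.1-fold lower number from compound 2 to compound 3 (0.03 log units; within the scatter), which is expected to stay within the scatter. Compound 3 is expected to give about 600 nM, with an estimated range from 260 nM to 1400 nM.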

Compound 3, concentration for 50% growth inhibition: 567 nM
Beside the measured number, compound 3's estimate is 1.1-fold (0.02 log units) above it; low and high end bracket the measured number.
By their numbers in this assay, from the lowest: compounds 1, 3 and 2 (each within the scatter of the next).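

In this assay the size of the carbon ring on this sulfur is now tested on its own: 2-hydroxycyclopentyl in place of 2-hydroxycyclohexyl gives a 1.1-fold lower number from compound 2 to compound 3 (0.05 log units; within the scatter) and so does not separate the five-membered ring from the six-membered ring. The comparison with the open chain gives the same kind of answer, since 2-hydroxycyclopentyl in place of 2-hydroxy-3-(piperazin-1-yl)propyl gives a 1.7-fold higher number from compound 1 to compound 3 (0.23 log units; within the scatter) and all three groups, each carrying a hydroxyl on a carbon chain or ring, therefore lie within the scatter of one another in this one assay. No measurement is available that could explain why these different groups give such similar numbers.

As far as these compounds go, it remains open whether the hydroxyl itself matters, which a plain cyclopentyl group on the same sulfur would test, and whether a simple amine without the hydroxyl would behave like the piperazine-bearing chain. From the compounds shown here alone, it is also open whether a carboxylic acid or a much longer carbon chain at this place would finally move the number beyond the scatter.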